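Methyl for fluoro on the benzoyl ring of the series

The source may report more compounds than this note shows. Statements on the series, on what has been measured and on what is new or still open speak of the compounds shown alone.

Of the compounds shown here, two have numbers so far. Compound 1 `O=C(COc1c(F)cc(C(=O)c2ccc(F)cc2)cc1Cl)NNC(=O)c1ccc(=O)oc1` gives 59900 nM in a functional assay on HeLa cells (Homo sapiens) for cytotoxicity, read by MTT assay, with a stated time of 48 h (on this read-out lower numbers stand for stronger inhibition and higher numbers for weaker inhibition), and compound 2 `Cn1cnc(C(=O)NNC(=O)COc2c(F)cc(C(=O)c3ccc(F)cc3)cc2Cl)c1` gives 42200 nM. Among the compounds with values here, the only measured step, a 1.4-fold lower number from compound 1 to compound 2 (0.15 log units; within the scatter), changes the group on the carbonyl carbon, not the fluorophenyl ring, so compound 2 stands lowest of two numbers but within the scatter of compound 1. Compound 3 `Cc1ccc(C(=O)c2cc(F)c(OCC(=O)NNC(=O)c3cn(C)cn3)c(Cl)c2)cc1` differs from compound 2 by methyl in place of fluoro on an aromatic carbon. Within the data shown here, no measured step bears on this place. The expected step is a 1.0-fold lower number from compound 2 to compound 3 (0.00 log units; within the scatter), nothing beyond the scatter. Compound 3 is estimated at 42000 nM, range 14000 nM to 130000 nM.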

Compound 3, half-maximal inhibitory concentration: 9900 nM
The estimate for compound 3 lay 4.2-fold (0.63 log units) above the measured number, outside the stated range (below it).
By their numbers in this assay, from the lowest: compound 3; then compounds 2 and 1 (each within the scatter of the next).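

Methyl in place of fluoro on the aromatic carbon para to a large group gives a 4.3-fold lower number from compound 2 to compound 3 (0.63 log units; beyond the scatter) in this assay, the first step in the series beyond the scatter. The only earlier step, on the carbonyl carbon, stayed within the scatter, so among these compounds this position is the one where the number moves. No measurement shown here accounts for the step.

From the compounds shown here alone, whether the lower number is specific to methyl stays open, since an ethyl, methoxy or amino group at this position would test that. Also open, going by these compounds, is whether the step carries over to the group of compound 1 on the carbonyl carbon.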